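Swapping the Amide Aryl Group on a Shared Core

This account rests on a few compounds, and the source may have more. Where it says the series, first, only, none or still open, it means among the compounds named here.

In a functional assay on SK-BR-3 cells (Homo sapiens) for antiproliferative activity, read by MTT assay, with a stated time of 72 h (a higher number here means a weaker inhibitor, a lower number a stronger inhibitor), compound 2 `CCN1CCN(c2cc(C)c3cc(NC(=O)c4ccc5ccccc5n4)ccc3n2)CC1` gives 3760 nM, the lowest number among the three measured here. Compound 3 `CNc1cc(C)c2cc(NC(=O)c3ccc(Cl)c(Cl)c3)ccc2n1` gives 6350 nM, and compound 1 `CCc1ccc(C(=O)Nc2ccc3nc(N4CCN(CC)CC4)cc(C)c3c2)cc1` gives 9850 nM. For the measured compounds named here, the only measured step at the carbonyl carbon, a 2.6-fold lower number from compound 1 to compound 2 (0.42 log units; beyond the scatter), was modest. Compound 4 `CCN1CCN(c2cc(C)c3cc(NC(=O)c4ccc(Cl)c(Cl)c4)ccc3n2)CC1` differs from compound 2 by 3,4-dichlorophenyl in place of quinolin-2-yl on a carbonyl carbon. Compound 3 carries the same 3,4-dichlorophenyl group but a different amine, and its value lies close to that of compound 2. Going by the values given here, with no directly comparable step, the expected change a 1.3-fold higher number from compound 2 to compound 4 (0.12 log units; within the scatter) is small, perhaps a slightly higher number. Compound 4 is therefore estimated at 5000 nM, with a likely range from 2000 nM to 12000 nM.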

Compound 4, half-maximal inhibitory concentration: 2160 nM
Compound 4: the middle estimate sits 2.3-fold (0.36 log units) above what was measured, and the stated range covers the measured number.
By their numbers in this assay, from the lowest: compounds 4, 2, 3 and 1 (each within the scatter of the next, the first and the last beyond it).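

In this assay the step of a 1.7-fold lower number from compound 2 to compound 4 (0.24 log units; within the scatter) stays within the scatter, leaving 3,4-dichlorophenyl and quinolin-2-yl on the carbonyl carbon indistinguishable, whereas a 4.6-fold lower number from compound 1 to compound 4 (0.66 log units; beyond the scatter) lies beyond it and sets 3,4-dichlorophenyl apart from 4-ethylphenyl. The amine counts as well: with the 3,4-dichlorophenyl amide held fixed, a 2.9-fold lower number from compound 3 to compound 4 (0.47 log units; beyond the scatter) comes with 4-ethylpiperazin-1-yl in place of methylamino on an aromatic carbon. No measured evidence explains these differences. From the compounds shown here alone, whether a pyridin-3-yl group on the carbonyl carbon, or a morpholine in place of 4-ethylpiperazin-1-yl, would shift the number remains open.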